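Working notes: a sulfamoyl step from compound 1

The compounds below may be only part of what the source reports. "The series", "measured", "known", "first", "only" and "open" are said of these compounds alone.

In a functional assay on HeLa cells (Homo sapiens) for antiproliferative activity, read by resazurin assay (a lower number here means a stronger inhibitor, a higher number a weaker inhibitor), compound 1 (`CCSC(=S)SCC(=O)c1ccc(NS(C)(=O)=O)cc1`) gives 39800 nM and compound 2 (`CC(C)SC(=S)SCC(=O)c1ccc(Cl)c(Cl)c1`) gives 25100 nM, two values within the scatter of each other. Compound 3 (`CCSC(=S)SCC(=O)c1ccc(S(N)(=O)=O)cc1`) keeps the core of compound 1 but carries sulfamoyl in place of methanesulfonamido on an aromatic carbon. Among the measured compounds shown here, no measured pair shows a step of this kind, so the expectation in this assay is no shift beyond the scatter. The estimated step is a 1.2-fold lower number from compound 1 to compound 3 (0.09 log units; within the scatter). Compound 3 is expected at 32000 nM, with an estimated range from 13000 nM to 80000 nM.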

Compound 3, half-maximal inhibitory concentration: 20000 nM
Beside the measured number, compound 3's estimate is 1.6-fold (0.20 log units) above it; low and high end bracket the measured number.
By their numbers in this assay, from the lowest: compounds 3, 2 and 1 (each within the scatter of the next).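

In this assay, among the compounds shown here, sulfamoyl in place of methanesulfonamido on an aromatic carbon gives a 2.0-fold lower number from compound 1 to compound 3 (0.30 log units; within the scatter) and is the first single-place step. This position therefore accepts this exchange, which removes one carbon and leaves the counted hydrogen-bond donor and acceptors unchanged, without a shift beyond the scatter. No available evidence bears on this result. Going by these compounds, whether a carboxylic acid or an amine on this aromatic carbon would move the number beyond the scatter remains open. A single step also leaves open whether the same exchange holds with a longer chain elsewhere on the shared core.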